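This account rests on a few compounds, and the source may have more. Where it says the series, first, only, none or still open, it means among the compounds named here.

In a functional assay on NCI-H460 cells (Homo sapiens) for antiproliferative activity, read by CCK-8 assay, with a stated time of 72 h, tested at 8 uM (on this read-out higher numbers stand for a stronger effect at the one concentration tested and lower numbers for a weaker effect), three compounds have been measured, each carrying an amide that bears an amino-substituted phenyl. Compound 1 `Nc1ccccc1NC(=O)/C=C/c1ccc(Cn2cnc3c(Nc4cccc(Cl)c4)nc(Cl)nc32)cc1` gives 29.4%. Compound 2 `CC(C)n1cnc2c(NCc3ccc(C(=O)Nc4ccccc4N)cc3)nc(Cl)nc21` gives 80.5%. Compound 3 `Nc1ccccc1NC(=O)c1ccc(COCNc2nc(Nc3ccccc3)c3ncn(C4CCCC4)c3n2)cc1` gives 56.1%, the second highest of the three numbers: compound 2 stands higher by a margin beyond the scatter, and compound 1 stands lower by a margin beyond the scatter. For the measured compounds named here, no two of the measured compounds differ in only one place, so no measured step bears directly on the change that leads to compound 4 `CCCCn1cnc2c(Nc3ccccc3)nc(NCOCc3ccc(C(=O)Nc4ccccc4N)cc3)nc21`. Compound 4 differs from compound 3 as follows: butyl in place of cyclopentyl on an aromatic nitrogen. Going by the values given here, nothing among the measured compounds shows how butyl in place of cyclopentyl on an aromatic nitrogen of the shared core moves the read-out, so the expectation rests on compound 3 alone. The step of a number 1.1 percentage points lower from compound 3 to compound 4 (within the scatter) is expected to be small, in either direction or none beyond the scatter. Compound 4 is estimated to give 55%, with a likely range from 35% to 75%.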

Compound 4, a percentage reported as inhibition, at one concentration (the size of the read-out at that concentration, not a potency): 51.3%
Compound 4: the middle estimate sits 3.7 percentage points above what was measured; the range from low to high includes it.
By their numbers in this assay, from the lowest: compound 1; then compounds 4 and 3 (each within the scatter of the next); then compound 2.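

In this assay, putting butyl in place of cyclopentyl on an aromatic nitrogen of the shared core gives a number 4.8 percentage points lower from compound 3 to compound 4 (within the scatter). At this position, then, an open chain and a five-membered carbon ring cannot be told apart by this read-out at the one concentration tested, so for this pair the ring is not required for the effect seen. No accompanying data bear on this result, and it stands without an explanation.

The compounds shown leave open whether this tolerance extends to a much shorter group such as methyl, a longer chain such as octyl, or a chain ending in an amine or a carboxylic acid. They also leave open whether the pair would still match at other concentrations, since a single-concentration read-out is not a potency.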